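The compounds below may be only part of what the source reports. "The series", "measured", "known", "first", "only" and "open" are said of these compounds alone.

For the measured compounds named here, in a functional assay on the whole organism with Scenedesmus acutus as the target, with a stated time of 20 h (on this read-out lower numbers stand for stronger inhibition and higher numbers for weaker inhibition), compound 3 (`C#CCOc1cc(N2C(=O)C3=C(CCCC3)C2=O)ccc1Cl`) gives 537 nM, the highest number of the three measured so far, with compound 1 (`CCCOC(=O)c1cc(N2C(=O)C3=C(CCCC3)C2=O)c(F)cc1Cl`) at 66.1 nM and compound 2 (`CCC(C)OC(=O)c1cc(N2C(=O)C3=C(CCCC3)C2=O)c(F)cc1Cl`) at 74.1 nM. Compound 4 (`C#CCOc1cc(N2C(=O)C3=C(CCCC3)C2=O)c(F)cc1Cl`) differs from compound 3 by one change, fluoro in place of hydrogen on an aromatic carbon. Going by the values given here, no measured step isolates this change. The only one available, a 1.1-fold higher number from compound 1 to compound 2 (0.05 log units; within the scatter), concerns the ester chain and says nothing direct about its size. The indirect evidence is that compound 1, at 66.1 nM, and compound 2, at 74.1 nM, both carry the fluoro group but have an ester instead of the propargyloxy group, so the comparison with compound 3 is confounded. A sizeable drop in this assay is therefore expected, with wide uncertainty, and the estimated step is a 7.7-fold lower number from compound 3 to compound 4 (0.88 log units; beyond the scatter). For compound 4 the expected value is 70 nM, with an estimated range of 20 nM to 220 nM.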

Compound 4, half-maximal inhibitory concentration: 141 nM
Compound 4: middle estimate off by 2.0-fold (0.30 log units), on the low side; measured number inside the range.
By their numbers in this assay, from the lowest: compounds 1, 2 and 4 (each within the scatter of the next, the first and the last beyond it); then compound 3.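

In this assay the position ortho to a large group and para to the propargyloxy group can now be read on its own: fluoro in place of hydrogen on this aromatic carbon gives a 3.8-fold lower number from compound 3 to compound 4 (0.58 log units; beyond the scatter) and thus moves the number beyond the scatter. With fluoro in place, propargyloxy in place of sec-butoxycarbonyl gives a 1.9-fold higher number from compound 2 to compound 4 (0.28 log units; within the scatter) and stays within the scatter, while propargyloxy in place of propoxycarbonyl gives a 2.1-fold higher number from compound 1 to compound 4 (0.33 log units; beyond the scatter) and lies modestly beyond it, so the propargyloxy compound stays close to both esters. Nothing available here explains the size of the fluoro step.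

On these data alone, whether chloro, methoxy or a nitrile on this same aromatic carbon would move the number as fluoro does remains open. So does whether the fluoro step carries over to the propoxycarbonyl and sec-butoxycarbonyl compounds.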